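Propanoyl to propylcarbonyl: working notes on the series

A few compounds are considered here, and "the series" means these few. Any claim that something is new, unique, unknown or untested is made for them only; others in the source may bear on it.

- Compound 1 `CC(=O)NNC(=O)c1csc2ncc(-c3ccc(C)cc3)n12` gives 92700 nM
- Compound 2 `CCC(=O)NNC(=O)c1csc2ncc(-c3ccc(C)cc3)n12` gives 18500 nM

In a functional assay on PC-3 cells (Homo sapiens) for antiproliferative activity, read by MTT assay, with a stated time of 72 h (on this read-out higher numbers stand for weaker inhibition and lower numbers for stronger inhibition), compound 2 holds the lower of the two numbers, at 18500 nM. Compound 3 `CCCC(=O)NNC(=O)c1csc2ncc(-c3ccc(C)cc3)n12` carries methyl in place of hydrogen on a saturated chain carbon, two bonds along the chain from a carbonyl carbon. Among the measured compounds shown here, one measured step bears on this: methyl in place of hydrogen on a saturated chain carbon bound to a carbonyl carbon, a 5.0-fold lower number from compound 1 to compound 2 (0.70 log units; beyond the scatter). That step is modest but beyond the scatter. As a single step, it sets a direction but shows no trend. A further modest fall in this assay is therefore expected, smaller than that step and possibly not beyond the scatter. The expected step is a 1.7-fold lower number from compound 2 to compound 3 (0.23 log units; within the scatter). The estimate for compound 3 is 11000 nM, with an expected range of 4000 nM to 30000 nM.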

Compound 3, half-maximal inhibitory concentration: 53500 nM
The estimate for compound 3 lay 4.9-fold (0.69 log units) below the measured number; the whole stated range lies below it.
By their numbers in this assay, from the lowest: compound 2; then compounds 3 and 1 (each within the scatter of the next).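

In this assay, the gain from the first added methyl does not carry on along the chain: methyl in place of hydrogen on a saturated chain carbon, two bonds along the chain from a carbonyl carbon, gives a 2.9-fold higher number from compound 2 to compound 3 (0.46 log units; beyond the scatter) and so reverses the direction. Across the whole ethyl change, on the saturated chain carbon bound to a carbonyl carbon, the result is a 1.7-fold lower number from compound 1 to compound 3 (0.24 log units; within the scatter) and leaves compound 2 as the lowest of the three, its steps to both others beyond the scatter. Nothing in hand accounts for this turn.

As far as these compounds go, whether a longer chain on this carbonyl carries the rise further or brings the number back down stays open. So does the behaviour of an isopropyl group, an amine or a carboxylic acid at the same place.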